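Benzyloxycarbonyl in place of methoxy on the shared core

This account rests on a few compounds, and the source may have more. Where it says the series, first, only, none or still open, it means among the compounds named here.

In a functional assay on A549 cells (Homo sapiens) for antiproliferative activity, read by MTT assay, with a stated time of 48 h (on this read-out higher numbers stand for weaker inhibition and lower numbers for stronger inhibition), compound 1 `c1ccc(-c2nn(-c3ccccc3)cc2-c2nc3ccccc3[nH]2)cc1` gives 2710 nM, compound 2 `Brc1ccc2[nH]c(-c3cn(-c4ccccc4)nc3-c3ccccc3)nc2c1` gives 1810 nM and compound 3 `COc1ccc2[nH]c(-c3cn(-c4ccccc4)nc3-c3ccccc3)nc2c1` gives 1230 nM. These numbers put the methoxy compound level with the bromo compound, with a 1.5-fold lower number from compound 2 to compound 3 (0.17 log units; within the scatter), and modestly under the compound carrying neither group, with a 2.2-fold lower number from compound 1 to compound 3 (0.34 log units; beyond the scatter).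

The next change leads to compound 4 `O=C(OCc1ccccc1)c1ccc2[nH]c(-c3cn(-c4ccccc4)nc3-c3ccccc3)nc2c1`, with benzyloxycarbonyl in place of methoxy on an aromatic carbon.

Among the compounds with values here, the steps that bear on it are those at this same carbon, and all are small. Alongside the two above stands a 1.5-fold lower number from compound 1 to compound 2 (0.18 log units; within the scatter). Within the data shown here, changing the group here has so far moved the number little, but none of the measured steps brings in a benzyloxycarbonyl, so the range has to stay wide.

In this assay the expected step is a 1.2-fold higher number from compound 3 to compound 4 (0.09 log units; within the scatter), which means no expected change beyond the scatter. Compound 4 is estimated at 1500 nM, with an expected range from 500 nM to 4500 nM.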

Compound 4, half-maximal inhibitory concentration: 19300 nM
Beside the measured number, compound 4's estimate is 13-fold (1.11 log units) below it; measured number above the stated range.
By their numbers in this assay, from the lowest: compounds 3, 2 and 1 (each within the scatter of the next, the first and the last beyond it); then compound 4.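

At this aromatic carbon the number is not indifferent to the group: among hydrogen, bromo and methoxy the steps were within the scatter or modest, whereas benzyloxycarbonyl brings a 16-fold higher number from compound 3 to compound 4 (1.20 log units; beyond the scatter) and an 11-fold higher number from compound 2 to compound 4 (1.03 log units; beyond the scatter) in this assay. Even against the compound carrying neither group there is a 7.1-fold higher number from compound 1 to compound 4 (0.85 log units; beyond the scatter), so benzyloxycarbonyl stands apart from all three earlier compounds, and the position that looked permissive for hydrogen, bromo and methoxy does not stay so for this group. Nothing among the data shown gives a measured reason for this rise.

From the compounds shown here alone, whether the rise goes with the benzyl part or with the carbonyl stays open, and a carboxylic acid, a methyl ester or a benzyloxy group at the same carbon would separate the two. Also open, going by these compounds, is where an amine or a primary amide would fall at this carbon on the same read-out.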